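Working notes: trifluoromethyl in place of hydroxy

A few compounds are considered here, and "the series" means these few. Any claim that something is new, unique, unknown or untested is made for them only; others in the source may bear on it.

Going by the values given here, compound 3 `OCCCCC#Cc1ccccc1C#Cc1ccc(O)cc1` gives 14100 nM in a functional assay on HCT-15 cells (Homo sapiens) for cytotoxicity (a lower number here means a stronger inhibitor of growth, a higher number a weaker inhibitor of growth), the second highest of the three numbers so far. Compound 2 `OCCCCC#Cc1ccccc1C#Cc1cccc(O)c1` gives 13600 nM, and the two numbers lie within the scatter (a 1.0-fold higher number from compound 2 to compound 3 (0.02 log units; within the scatter)). Compound 1 `OCCCCC#Cc1ccccc1C#Cc1ccccn1` gives 29800 nM; from it a 2.2-fold lower number from compound 1 to compound 2 (0.34 log units; beyond the scatter) and a 2.1-fold lower number from compound 1 to compound 3 (0.32 log units; beyond the scatter). Compound 4 `OCCCCC#Cc1ccccc1C#Cc1ccc(C(F)(F)F)cc1` carries trifluoromethyl in place of hydroxy on an aromatic carbon. Among the compounds with values here, no measured step exchanges hydroxy for trifluoromethyl; the steps seen concern pyridin-2-yl against a hydroxyphenyl and 3-hydroxyphenyl against 4-hydroxyphenyl, so none bears directly on this change. The three numbers span a narrow range, and no step beyond the scatter is expected: the estimated step is a 1.1-fold higher number from compound 3 to compound 4 (0.03 log units; within the scatter). Compound 4 is therefore expected at 15000 nM, with a range from 5000 nM to 45000 nM.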

Compound 4, concentration for 50% growth inhibition: 12500 nM
For compound 4 the middle estimate is 1.2-fold (0.08 log units) above the measured one; the range from low to high includes it.
By their numbers in this assay, from the lowest: compounds 4, 2 and 3 (each within the scatter of the next); then compound 1.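

Trifluoromethyl in place of hydroxy on an aromatic carbon, para to a large group, gives a 1.1-fold lower number from compound 3 to compound 4 (0.05 log units; within the scatter) in this assay. Going by these compounds alone, no earlier step removes the hydroxy from this ring; here the entering group has 0 hydrogen-bond donors and 0 hydrogen-bond acceptors, yet the step stays within the scatter. No available data account for this result.

The compounds shown leave open whether an amine or a carboxylic acid on this aromatic carbon would give a step beyond the scatter. As far as these compounds go, the effect of a longer chain in place of the trifluoromethyl also remains open.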